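Hydroxy for Trifluoromethyl on a Trimethoxyphenyl Benzimidazole Core

The source may hold more compounds than are shown below. What is called first, only, known or untested is meant among the compounds shown, and "the series" means these compounds.

Compound 1: `COc1cc(-n2cnc3ccc(-c4ccc(C(F)(F)F)cc4)cc32)cc(OC)c1OC` — 890 nM
Compound 2: `COc1cc(-c2ccc3ncn(-c4cc(OC)c(OC)c(OC)c4)c3c2)cc(OC)c1OC` — > 10000 nM

Of the compounds shown here, two have been measured in a functional assay on SGC-7901 cells (Homo sapiens) for antiproliferative activity, read by MTT assay, with a stated time of 72 h; a lower number here means a stronger inhibitor, a higher number a weaker inhibitor. Compound 1 gives 890 nM, the only number shown for this set. For compound 2 the result is a limit of the assay, > 10000 nM, and not a number; it sits at the limit of > 10000 nM in this assay, at which 1 of the 2 values shown sits. Going by the values given here, compound 1 therefore stands as the one compound here with a defined value, with no measured step to compare it against.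

The next compound, compound 3, is `COc1cc(-n2cnc3ccc(-c4ccc(O)cc4)cc32)cc(OC)c1OC`. It differs from compound 1 in one place: hydroxy in place of trifluoromethyl on an aromatic carbon. Among the compounds with values here, no step between measured compounds of this kind is available, so the size of the change can only be expected, not read off. For compound 3 a modest loss of potency, close to the scatter of this assay, is the estimate, with the expected step from compound 1 to compound 3 in this assay being a 1.8-fold higher number from compound 1 to compound 3 (0.25 log units; within the scatter). Compound 3 is thus estimated at 1600 nM, within a range from 400 nM to 6500 nM.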

Compound 3, half-maximal inhibitory concentration: > 10000 nM
Compound 3 ended at the assay's limit; the forecaster's own chance of this, stated with the estimate: 12%; middle value at least 6.2-fold (0.79 log units) away from the limit.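

With compound 3 there is now a measured step at this position: in this assay, hydroxy in place of trifluoromethyl on this aromatic carbon gives an at least 11-fold higher number from compound 1 to compound 3 (1.05 log units; beyond the scatter). The group at this position therefore matters to the read-out, and among the compounds shown only compound 1, with its 4-(trifluoromethyl)phenyl group, has a defined value. The size of the step is a minimum and not a measurement, and compound 3 cannot be ranked against compound 2, as the value of compound 3 is a limit of the assay shared by both: the limit of > 10000 nM in this assay, at which 2 of the 3 values shown sit.

Going by these compounds, how far the number rises beyond that minimum remains open. Also open, on these data alone, is how a methoxy, a chlorine, an amine or a carboxylic acid at this position would read in this assay.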